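Removing One Methoxy Group from Compound 3

The source may hold more compounds than are shown below. What is called first, only, known or untested is meant among the compounds shown, and "the series" means these compounds.

Measured in an assay on isolated protein for inhibition of Maltase-glucoamylase (Homo sapiens), with a stated time of 15 min; a higher number here means a weaker inhibitor, a lower number a stronger inhibitor:
compound 1 `O=C(N/N=C/c1ccc(O)cc1)c1ccc(-c2nc3ccccc3s2)cc1`: 11300 nM
compound 2 `O=C(N/N=C/c1ccccc1O)c1ccc(-c2nc3ccccc3s2)cc1`: 5550 nM
compound 3 `COc1cc(/C=N/NC(=O)c2ccc(-c3nc4ccccc4s3)cc2)cc(OC)c1`: 16200 nM

Compound 3 gives the highest number of the three; it sits close to compound 1, since a 1.4-fold higher number from compound 1 to compound 3 (0.16 log units; within the scatter), and clearly apart from compound 2, since a 2.9-fold higher number from compound 2 to compound 3 (0.47 log units; beyond the scatter). Compound 4 `COc1cccc(/C=N/NC(=O)c2ccc(-c3nc4ccccc4s3)cc2)c1` differs from compound 3 by hydrogen in place of methoxy on an aromatic carbon. No measured step removes a methoxy group, so the steps shown bear only indirectly: the ring changes among compounds 1, 2 and 3 moved the number modestly at most. A change of similar or smaller size is therefore expected, most likely toward a lower number, though a result within the scatter would not surprise. Compound 4 is expected to give about 12000 nM in this assay, between 5000 nM and 30000 nM, which would mean a 1.4-fold lower number from compound 3 to compound 4 (0.13 log units; within the scatter).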

Compound 4, half-maximal inhibitory concentration: 11100 nM
Compound 4: middle estimate off by 1.1-fold (0.03 log units), on the high side; the range from low to high includes it.
By their numbers in this assay, from the lowest: compounds 2, 4, 1 and 3 (each within the scatter of the next, the first and the last beyond it).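

In this assay, taking one methoxy group off this aromatic carbon leaves the number within the scatter (a 1.5-fold lower number from compound 3 to compound 4 (0.16 log units; within the scatter)), so at this level of inhibition the second methoxy group shows no measurable contribution. Nor can compound 4 be told apart from its two hydroxyphenyl relatives (a 1.0-fold lower number from compound 1 to compound 4 (0.01 log units; within the scatter); a 2.0-fold higher number from compound 2 to compound 4 (0.30 log units; within the scatter)), although compound 3 stands clearly apart from compound 2. No measurement shown here explains these small differences. As far as these compounds go, whether an amine, a carboxylic acid or a longer chain on this aromatic carbon would move the number beyond the scatter stays open.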